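The source may report more compounds than this note shows. Statements on the series, on what has been measured and on what is new or still open speak of the compounds shown alone.

Measured so far:
compound 1 `COc1ccc(OC)c(C2CC(c3ccncc3)=NN2)c1` gives 13% in a functional assay on the whole organism (strain Charles Foster albino) for inhibition, with Rattus norvegicus as the target, read by paw edema, with stated times of 30 min and 3 h, at a dose of 50 mg/kg by the oral route; on this read-out higher numbers stand for more inhibition at the one dose given (going by the name of the read-out) and lower numbers for less inhibition;
compound 2 `COc1ccc(OC)c(C2CC(c3cccnc3)=NN2)c1` gives 15% in this assay;
compound 3 `CN(C)c1ccc(C2CC(c3cccnc3)=NN2c2ccccc2)cc1` gives 34% in this assay.

Compound 3 stands highest, its nearest neighbour being compound 2, the gap being beyond the scatter. The difference between the core of compound 3 and that of compound 2 is not broken down here. Compound 4 `CN(C)c1ccc(C2CC(c3ccncc3)=NN2c2ccccc2)cc1` is still to be measured. It differs from compound 3 by pyridin-4-yl in place of pyridin-3-yl on a carbon with a double bond to nitrogen, and compound 1 differs from compound 2 by pyridin-4-yl in place of pyridin-3-yl on a carbon with a double bond to nitrogen, the same kind of change, though the place lines differ: in compound 3 the ring atom two bonds away bears a group of 9 heavy atoms and another ring atom bears a phenyl group, whereas in compound 2 the corresponding atom bears a large group. The earlier step was a number 2 percentage points lower from compound 2 to compound 1 (within the scatter), and a step of similar size is expected, a number 2 percentage points lower from compound 3 to compound 4 (within the scatter), because compound 3 gives 34%. Compound 4 is therefore estimated at 32%, between 20% and 44%.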

Compound 4, a percentage reported as inhibition, in the whole organism at one dose (the size of the read-out at that dose, not a potency): 32%
The estimate for compound 4 equals the measured number at the digits printed; the range from low to high includes it.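

In this assay, pyridin-4-yl in place of pyridin-3-yl gives a number 2 percentage points lower from compound 3 to compound 4 (within the scatter), and the change reads the same on both cores: the same change on two cores in this assay, a number 2 percentage points lower (within the scatter) from compound 2 to compound 1 and a number 2 percentage points lower (within the scatter) from compound 3 to compound 4, 0 percentage points apart, within the scatter of two such steps This shows that on these two cores the swap leaves the read-out within the scatter, so the small step carries over from one to the other. It does not show that the step would hold on any further core, and two steps within the scatter say little about how a larger effect would transfer.

The compounds shown leave open what a pyridin-2-yl group or a carboxylic acid on the carbon with a double bond to nitrogen would do. Going by these compounds, whether either would move the read-out beyond the scatter remains unknown.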